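Changing the Group on the Ring Nitrogen of a Shared Core

The source may report more compounds than this note shows. Statements on the series, on what has been measured and on what is new or still open speak of the compounds shown alone.

Measured compounds:
compound 1 `Cc1nc(S(C)(=O)=O)ccc1Oc1ncnc(OC2CCN(C(=O)OC3COC3)CC2)c1F`: 2500 nM in a functional assay on isolated protein for inhibition of Glucose-dependent insulinotropic receptor (Rattus norvegicus), read by HTRF and cAMP accumulation; on this read-out higher numbers stand for an effect only at larger amounts of compound and lower numbers for an effect already at smaller amounts
compound 2 `Cc1nc(S(C)(=O)=O)ccc1Oc1ncnc(OC2CCN(C(=S)OC3(C)CC3)CC2)c1F`: 48.8 nM in this assay

Within the data shown here, compound 2 holds the lowest of the two numbers measured so far in this assay; its nearest neighbour is compound 1, and the step of a 51-fold lower number from compound 1 to compound 2 (1.71 log units; beyond the scatter) shows how far the two lie apart, well beyond the scatter. That single step is the only one that bears on the new compound, and it tells that the group on the amine nitrogen in the ring can move the read-out a long way.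

Compound 3 `Cc1nc(S(C)(=O)=O)ccc1Oc1ncnc(OC2CCN(C(=O)C(C)(C)F)CC2)c1F` is the untested member. Its difference from compound 2 is a group of 6 heavy atoms (4 carbon, 1 oxygen, 1 fluorine; no ring) in place of a group of 7 heavy atoms (5 carbon, 1 oxygen, 1 sulfur; one three-membered non-aromatic ring of carbon only), on an amine nitrogen in a ring. Among the measured compounds shown here, the entering (1-fluoro-1-methylethyl)carbonyl sits at the same place as the groups that distinguish compound 1 from compound 2, so a change of comparable size is possible, but nothing measured shows whether this particular group behaves more like the one in compound 1 or the one in compound 2. On that basis compound 3 is expected to land between the two, giving a step of a 3.1-fold higher number from compound 2 to compound 3 (0.49 log units; beyond the scatter) toward a higher number. The estimate for compound 3 in this assay is 150 nM, with a range from 35 nM to 650 nM.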

Compound 3, half-maximal effective concentration: 296 nM
For compound 3 the middle estimate is 2.0-fold (0.30 log units) below the measured one, within the range that was stated.
By their numbers in this assay, from the lowest: compound 2; then compound 3; then compound 1.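

In this assay, the amine nitrogen in the ring now carries a third group, and the (1-fluoro-1-methylethyl)carbonyl places compound 3 in the interval set by the two earlier compounds, with an 8.4-fold lower number from compound 1 to compound 3 (0.93 log units; beyond the scatter) on one side and a 6.1-fold higher number from compound 2 to compound 3 (0.78 log units; beyond the scatter) on the other. The step from compound 1 is the more informative one, as the carbonyl stays and only 1-fluoro-1-methylethyl replaces (oxetan-3-yl)oxy on the carbonyl carbon, showing that this exchange alone moves the read-out beyond the scatter, whereas the earlier step also brought in sulfur. Nothing on hand accounts for the size or direction of either step.

The step from compound 2 changes the sulfur, the oxygen link and the three-membered ring together, so the compounds shown leave open which of these features goes with the lower number of compound 2. Also open, from the compounds shown here alone, is how the read-out would respond on that carbonyl carbon to an isopropyl group, which would replace the fluorine of 1-fluoro-1-methylethyl with hydrogen, or to a cyclopropyl group or an amine.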